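The source may report more compounds than this note shows. Statements on the series, on what has been measured and on what is new or still open speak of the compounds shown alone.

Measured compounds:
Compound 1 `Cc1ccc(S(=O)(=O)N2CCC(Cl)=CC2CC(C)C)cc1` — 21000 nM
Compound 2 `Cc1ccc(S(=O)(=O)N2CCC(Cl)=CC2C2CCCCC2)cc1` — 24000 nM

In a functional assay on WiDr cells (Homo sapiens) for antiproliferative activity, read by sulforhodamine B assay, with a stated time of 48 h (on this read-out lower numbers stand for stronger inhibition of growth and higher numbers for weaker inhibition of growth), compound 1 gives 21000 nM and compound 2 gives 24000 nM. Compound 2 stands alongside compound 1: the step of a 1.1-fold higher number from compound 1 to compound 2 (0.06 log units; within the scatter) lies within the scatter, so the two numbers cannot be told apart on this read-out. Compound 3 `Cc1ccc(S(=O)(=O)N2CCC(Cl)=CC2c2ccccc2)cc1` differs from compound 2 by phenyl in place of cyclohexyl on a saturated ring carbon. Going by the values given here, the only measured step that bears on this change is the one at the same ring carbon, a 1.1-fold higher number from compound 1 to compound 2 (0.06 log units; within the scatter), where a different group at that position left the number essentially unmoved. On that basis a step of a 1.1-fold lower number from compound 2 to compound 3 (0.04 log units; within the scatter) is expected from compound 2 to compound 3, that is, nothing beyond the scatter. Compound 3 is therefore estimated at 22000 nM in this assay, within a range from 9000 nM to 55000 nM.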

Compound 3, concentration for 50% growth inhibition: 18000 nM
Beside the measured number, compound 3's estimate is 1.2-fold (0.09 log units) above it, within the range that was stated.
By their numbers in this assay, from the lowest: compounds 3, 1 and 2 (each within the scatter of the next).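

Until now only non-aromatic groups had been seen on this saturated ring carbon; the phenyl group shows that an aromatic ring can stand there too without a change that can be read in this assay. Exchanging cyclohexyl for phenyl, which keeps the count of heavy atoms but makes the ring aromatic, gives a 1.3-fold lower number from compound 2 to compound 3 (0.12 log units; within the scatter), and exchanging isobutyl for phenyl gives a 1.2-fold lower number from compound 1 to compound 3 (0.07 log units; within the scatter), so the three groups cannot be told apart on this read-out. Nothing at hand accounts for this lack of difference.

The three groups shown are all hydrocarbons, so it remains open whether an amine, a carboxylic acid or a hydroxyl group on this carbon would move the number beyond the scatter. Also open, on these data alone, is what a methyl group, a longer chain or a substituted phenyl would do there.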